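This account rests on a few compounds, and the source may have more. Where it says the series, first, only, none or still open, it means among the compounds named here.

Three measured compounds share one core and differ only in the group on a single aromatic carbon. Compound 1 `COc1ccc(-c2cnc(Nc3ccc(C#N)cc3)nc2Oc2c(C)cc(C#N)cc2C)cc1` carries a 4-methoxyphenyl there. In an ADME assay on MT4 cells (Homo sapiens) for cytotoxicity, read by MTT assay, with a stated time of 5 days (a higher number here means that more compound is tolerated, a lower number that less compound is tolerated), compound 1 gives only a limit, > 279000 nM, not a number. Compound 2 `Cc1cc(C)cc(-c2cnc(Nc3ccc(C#N)cc3)nc2Oc2c(C)cc(C#N)cc2C)c1` carries a 3,5-dimethylphenyl, and in this assay compound 2 gives 39000 nM, the highest of the two numbers recorded. Compound 3 `Cc1cc(C#N)cc(C)c1Oc1nc(Nc2ccc(C#N)cc2)ncc1-c1cccnc1` carries a pyridin-3-yl, and in this assay compound 3 gives 13500 nM. The measured steps are an at least 7.1-fold lower number from compound 1 to compound 2 (0.85 log units; beyond the scatter), an at least 20-fold lower number from compound 1 to compound 3 (1.31 log units; beyond the scatter) and a 2.9-fold lower number from compound 2 to compound 3 (0.46 log units; beyond the scatter).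

Compound 4 `Cc1cc(C#N)cc(C)c1Oc1nc(Nc2ccc(C#N)cc2)ncc1-c1ccncc1` has not yet been measured. It differs from compound 2 in one place: pyridin-4-yl in place of 3,5-dimethylphenyl on an aromatic carbon. For the measured compounds named here, the closest precedent is a 2.9-fold lower number from compound 2 to compound 3 (0.46 log units; beyond the scatter), where a pyridin-3-yl also replaced the 3,5-dimethylphenyl, so a modest drop in this assay is expected here as well. Compound 4 is therefore estimated at 15000 nM, within a range of 5000 nM to 40000 nM. That estimate means an expected step of a 2.6-fold lower number from compound 2 to compound 4 (0.41 log units; beyond the scatter).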

Compound 4, half-maximal cytotoxic concentration: 28000 nM
Beside the measured number, compound 4's estimate is 1.9-fold (0.27 log units) below it, within the range that was stated.
By their numbers in this assay, from the lowest: compound 3; then compounds 4 and 2 (each within the scatter of the next). At a limit, above all of these: compound 1.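

The position of the ring nitrogen matters at this carbon: in this assay, moving from pyridin-3-yl to pyridin-4-yl gives a modest change (a 2.1-fold higher number from compound 3 to compound 4 (0.32 log units; beyond the scatter)). Replacing a carbon-only ring with a pyridine therefore does not always shift the number, since the step to pyridin-4-yl stays small (a 1.4-fold lower number from compound 2 to compound 4 (0.14 log units; within the scatter)), while compound 3 goes against any such general drop. The value of compound 1 is a limit and not a number, so its step (an at least 9.9-fold lower number from compound 1 to compound 4 (0.99 log units; beyond the scatter)) gives only a bound: the limit of > 279000 nM in this assay, at which 1 of the 4 values shown sits.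

The compounds shown leave open whether a pyridin-2-yl would fall nearer compound 3 or compound 4. They also leave open how a phenyl ring carrying an amine or a carboxylic acid would behave at this carbon.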